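The source may report more compounds than this note shows. Statements on the series, on what has been measured and on what is new or still open speak of the compounds shown alone.

Compound 1 `CNCc1ccc2c(c1)nc(Cn1c(=O)n(C(C)C)c3ccccc31)n2CCC(C)C`: 1480 nM
Compound 2 `CC(C)CCn1c(Cn2c(=O)n(CC(=O)O)c3ccccc32)nc2cc(C(=N)N)ccc21`: 173000 nM
Compound 3 `COC(=O)c1cccc2nc(Cn3c(=O)n(C(C)C)c4ccccc43)n(CCC(C)C)c12`: 25300 nM

In an ADME assay on HEp-2 cells (Homo sapiens) for cytotoxicity (a lower number here means that less compound is tolerated, a higher number that more compound is tolerated), compound 1 has the lowest number of the three, and the gaps to compound 3 and compound 2 both lie beyond the scatter. Compound 4 `CC(C)CCn1c(Cn2c(=O)n(C(C)C)c3ccccc32)nc2cc(Br)ccc21` is not yet measured. It carries bromo in place of (methylamino)methyl on an aromatic carbon. Going by the values given here, no measured pair isolates this change. Compound 3 also lacks the (methylamino)methyl group and gives 25300 nM, so a rise beyond the scatter is expected in this assay. The expected step is a 14-fold higher number from compound 1 to compound 4 (1.13 log units; beyond the scatter). For compound 4 the estimate is 20000 nM, with an expected range of 5000 nM to 80000 nM.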

Compound 4, half-maximal cytotoxic concentration: 18100 nM
The estimate for compound 4 lay 1.1-fold (0.04 log units) above the measured number; the measured number falls inside the stated range.
By their numbers in this assay, from the lowest: compound 1; then compounds 4 and 3 (each within the scatter of the next); then compound 2.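

In this assay, going by these compounds alone, bromo in place of (methylamino)methyl on an aromatic carbon gives a 12-fold higher number from compound 1 to compound 4 (1.09 log units; beyond the scatter) and is the first reading of this position with the rest of compound 1 unchanged. Within the data shown here, the low number of compound 1 thus goes with the (methylamino)methyl group in this pair, a link the earlier compounds, differing in several places, could not isolate.

Open, going by these compounds, is whether another amine, such as dimethylaminomethyl or aminomethyl, or plain hydrogen at this carbon would give a number nearer compound 1 or compound 4, since a single pair cannot separate the loss of (methylamino)methyl from the entry of bromo. Nothing measured here gives a reason for the step.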